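This account rests on a few compounds, and the source may have more. Where it says the series, first, only, none or still open, it means among the compounds named here.

Of the compounds shown here, two sharing one core have been measured in a functional assay on SW480 cells (Homo sapiens) for inhibition, read by luminescence and resazurin assay, with a stated time of 3 days; on this read-out lower numbers stand for stronger inhibition and higher numbers for weaker inhibition. Compound 1 `CNc1nc(NCc2ccc(NC(=O)c3ccncc3)cc2)c2ccccc2n1` gives only a limit of the assay, > 20000 nM. Compound 2 `CNc1nc(NCc2ccc(C(=O)Nc3ccc(F)cc3)cc2)c2ccccc2n1` gives 4100 nM, the only plain number shown, so it is the sole anchor. The measured step of an at least 4.8-fold lower number from compound 1 to compound 2 (0.68 log units; beyond the scatter) concerns a different part of the molecule. Compound 3 `O=C(Nc1ccc(F)cc1)c1ccc(CNc2nc(NC3CC3)nc3ccccc23)cc1` differs from compound 2 by cyclopropyl in place of methyl on a nitrogen on an aromatic ring. Within the data shown here, no measured step touches this position, so the step expected is small, a 1.4-fold lower number from compound 2 to compound 3 (0.14 log units; within the scatter). Compound 3 is therefore estimated at 3000 nM, with a range from 1000 nM to 10000 nM.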

Compound 3, half-maximal inhibitory concentration: 2600 nM
Beside the measured number, compound 3's estimate is 1.2-fold (0.06 log units) above it; the measured number falls inside the stated range.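

Going from methylamino to cyclopropylamino in this assay gives a 1.6-fold lower number from compound 2 to compound 3 (0.20 log units; within the scatter), so this nitrogen carries the cyclopropyl as well as the methyl, with no difference that can be told from the scatter. Among these compounds, this is the first reading at this position, since the earlier step concerned a different part of the molecule. Nothing shown offers an explanation for this result. Still open, from the compounds shown here alone, is whether a longer chain such as butyl on this nitrogen would move the number beyond the scatter. The same holds for a chain ending in an amine or a carboxylic acid.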